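A Ring Swap on the Chain in Two Core Settings

The compounds below may be only part of what the source reports. "The series", "measured", "known", "first", "only" and "open" are said of these compounds alone.

Three compounds built around a shared core were tested in an assay on LX2 cells for inhibition of COL1A1 promoter (Homo sapiens), read by a luciferase reporter, with a stated time of 24 h, tested at 20 uM; on this read-out higher numbers stand for a stronger effect at the one concentration tested and lower numbers for a weaker effect. Compound 1 `Cc1cc(OCCCCCCC[N+]23CCN(CC2)CC3)cc(-n2cc(C(=O)Nc3cc(F)cc(F)c3)c(=O)c3ccc(N(C)C)nc32)c1` gives 10.3% in this assay. Compound 2 `Cc1ccc(-n2cc(C(=O)Nc3cc(F)cc(F)c3)c(=O)c3ccc(N(C)C)nc32)cc1OCCCCCCC[N+]12CCN(CC1)CC2` has a core that holds the same atoms as that of compound 1 joined differently; the difference between the two cores is not broken down here. In this assay compound 2 gives 5.07%. Compound 3 `Cc1cc(OCCCCCCC[N+]2(C)CCCC2)cc(-n2cc(C(=O)Nc3cc(F)cc(F)c3)c(=O)c3ccc(N(C)C)nc32)c1` gives 4.32%.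

Compound 3 arises from compound 1 by one change: a group of 6 heavy atoms (5 carbon, 1 nitrogen; one five-membered non-aromatic ring with 1 hetero atom) in place of a group of 8 heavy atoms (6 carbon, 2 nitrogen; 2 six-membered non-aromatic rings with 2 hetero atoms each), on a saturated chain carbon, seven bonds along the chain from an oxygen on an aromatic ring The step this change made was a number 6 percentage points lower from compound 1 to compound 3 (within the scatter). The same change applied to compound 2 gives compound 4 `Cc1ccc(-n2cc(C(=O)Nc3cc(F)cc(F)c3)c(=O)c3ccc(N(C)C)nc32)cc1OCCCCCCC[N+]1(C)CCCC1`, which has not yet been measured: a group of 6 heavy atoms (5 carbon, 1 nitrogen; one five-membered non-aromatic ring with 1 hetero atom) in place of a group of 8 heavy atoms (6 carbon, 2 nitrogen; 2 six-membered non-aromatic rings with 2 hetero atoms each), on a saturated chain carbon, seven bonds along the chain from an oxygen on an aromatic ring The place of the change is described in the same words for both pairs, so it is the same change set on a different core. The step from compound 2 to compound 4 in this assay is expected to be a number 3.6 percentage points lower from compound 2 to compound 4 (within the scatter), close to the earlier one, because the step of a number 6 percentage points lower from compound 1 to compound 3 (within the scatter) stayed within the scatter and the two cores hold the same atoms. Compound 4 is therefore estimated to give 1.5%, with a range from -9% to 12%.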

Compound 4, a percentage reported as inhibition, at one concentration (the size of the read-out at that concentration, not a potency): 12.7%
Compound 4: the middle estimate sits 11.2 percentage points below what was measured; measured number above the stated range.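

In this assay, the ring swap on the chain, set on the core of compound 2, gave a number 7.6 percentage points higher from compound 2 to compound 4 (within the scatter). Set beside the same swap on the core of compound 1, the two steps point in opposite directions, yet they do not differ beyond what repeated measurements of this kind would produce: the same change on two cores in this assay, a number 6 percentage points lower (within the scatter) from compound 1 to compound 3 and a number 7.6 percentage points higher (within the scatter) from compound 2 to compound 4, 13.6 percentage points apart, within the scatter of two such steps. This gives no sign that the core alters the effect of the swap, but since each step also lies within the scatter, it does not show that the swap has a reliable effect of its own on either core, or that such an effect carries from one core to the other.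

The compounds shown leave open what other groups at the end of the chain, such as a simple tertiary amine, a piperidine or a carboxylic acid, or a longer or shorter chain, would do in this series. They also leave open how any of these compounds would read across a range of concentrations.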